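This account rests on a few compounds, and the source may have more. Where it says the series, first, only, none or still open, it means among the compounds named here.

In a functional assay on HeLa cells (Homo sapiens) for antiproliferative activity, read by sulforhodamine B assay, with a stated time of 72 h (on this read-out higher numbers stand for weaker inhibition and lower numbers for stronger inhibition), compound 1 (`COc1ccccc1NC(=S)N/N=C/c1ccc2ccccc2n1`) reports only the limit of > 100000 nM, so no number is known for it. Because the limit of > 100000 nM in this assay, at which 1 of the 3 values shown sits, applies, compound 1 cannot be placed against the others. Compound 2 (`CN(C)C(=S)N/N=C/c1cc2cccnc2s1`) gives 48400 nM in this assay, and compound 3 (`NC(=S)N/N=C/c1cc2cccnc2s1`) gives 6290 nM. Going by the values given here, the one measured step that bears on the change, a 7.7-fold lower number from compound 2 to compound 3 (0.89 log units; beyond the scatter), also removed substituents from the nitrogen next to the thiocarbonyl carbon. Compound 4 (`NC(=S)N/N=C/c1ccc2ccccc2n1`) differs from compound 1 by hydrogen in place of 2-methoxyphenyl on an amide-type nitrogen. By analogy with the step of a 7.7-fold lower number from compound 2 to compound 3 (0.89 log units; beyond the scatter), a lower number is expected for compound 4 in this assay. The expected step of an at least 12-fold lower number from compound 1 to compound 4 (1.09 log units; beyond the scatter) is an estimate starting from a limit, not a measured change. Compound 4 is expected to give about 8000 nM, between 1500 nM and 50000 nM.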

Compound 4, half-maximal inhibitory concentration: 960 nM
Compound 4: middle estimate off by 8.3-fold (0.92 log units), on the high side; the whole stated range lies above it.
By their numbers in this assay, from the lowest: compound 4; then compound 3; then compound 2. At a limit, above all of these: compound 1.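

With hydrogen in place of 2-methoxyphenyl on the amide-type nitrogen, this assay shows an at least 100-fold lower number from compound 1 to compound 4 (2.01 log units; beyond the scatter). The earlier step, a 7.7-fold lower number from compound 2 to compound 3 (0.89 log units; beyond the scatter), involved only amino in place of dimethylamino, so this result extends the trend to a large aromatic substituent on a different core. The new step is a bound rather than an exact size because compound 1 stands only at a limit: the limit of > 100000 nM in this assay, at which 1 of the 4 values shown sits.

The compounds shown leave open whether a methyl group or an unsubstituted phenyl on this nitrogen would retain the lower number. They also leave open how much of the step depends on the methoxy group.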